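This account rests on a few compounds, and the source may have more. Where it says the series, first, only, none or still open, it means among the compounds named here.

Measured in a functional assay on SK-OV-3 cells (Homo sapiens); on this read-out higher numbers stand for weaker inhibition of growth and lower numbers for stronger inhibition of growth:
Compound 1 `O=S(=O)(/C=C/c1ccc(F)cc1)Cc1ccc(Nc2ncnc3ccccc23)cc1`: 2000 nM
Compound 2 `O=S(=O)(/C=C/c1ccc(F)cc1F)Cc1ccc(Nc2ncnc3ccccc23)cc1`: 69000 nM
Compound 3 `COc1cc2ncnc(Nc3ccc(CS(=O)(=O)/C=C/c4ccc(Cl)cc4Cl)cc3)c2cc1OC`: 2000 nM

Compound 3 gives 2000 nM in this assay, level with compound 1 and far below compound 2. Compound 4 `COc1cc2ncnc(Nc3ccc(CS(=O)(=O)/C=C/c4ccc(F)cc4)cc3)c2cc1OC` keeps the core of compound 3 and differs from it in one place: 4-fluorophenyl in place of 2,4-dichlorophenyl on a double-bonded chain carbon bound to a double-bonded chain carbon. In words, 4-fluorophenyl stands in place of 2,4-dichlorophenyl on a double-bonded chain carbon bound to a double-bonded chain carbon.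

Going by the values given here, only one measured step bears on this change: a 35-fold higher number from compound 1 to compound 2 (1.54 log units; beyond the scatter). There, fluoro in place of hydrogen on an aromatic carbon made a large difference, so a ring carrying less halogen might be expected to give a lower number. That step is only a loose guide, however, since it was measured on a different core and involved fluoro rather than chloro. Compound 3, with its 2,4-dichlorophenyl, still gives 2000 nM, so the large penalty seen for compound 2 does not simply carry over. The 4-fluorophenyl of compound 4 also stands on a different core in compound 1, which gives 2000 nM. A small estimated change is therefore expected, toward a lower number if there is any: a 1.7-fold lower number from compound 3 to compound 4 (0.22 log units; within the scatter). For compound 4 the expected value is 1200 nM, with an estimated range from 250 nM to 6000 nM.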

Compound 4, concentration for 50% growth inhibition: > 100000 nM
Compound 4: a limit, no number; the forecaster's own chance of this, stated with the estimate: 3%; middle value at least 83-fold (1.92 log units) from the limit.
By their numbers in this assay, from the lowest: compounds 1 and 3 (each within the scatter of the next); then compound 2. At a limit, above all of these: compound 4.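

In this assay, the ring on a double-bonded chain carbon bound to a double-bonded chain carbon turns out to matter a great deal on the core shared by this pair: changing 2,4-dichlorophenyl to 4-fluorophenyl gives an at least 50-fold higher number from compound 3 to compound 4 (1.69 log units; beyond the scatter). The earlier step, a 35-fold higher number from compound 1 to compound 2 (1.54 log units; beyond the scatter), came with one more fluoro on this ring, whereas the new step comes with one halogen fewer, yet both go toward a higher number, so the count of halogens alone does not order these compounds. Compound 4 stands at a limit and has no exact number: the limit of > 100000 nM in this assay, at which 1 of the 4 values shown sits.

The compounds shown leave open whether the gain in compound 3 comes from the kind of halogen, chlorine rather than fluorine, or from the number of halogens on the ring, and a phenyl ring carrying a single chlorine on the same core would help separate the two. They also leave open how a plain phenyl ring, or a ring carrying a methoxy group or an amine instead of halogen, would read at this place.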